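A Methyl Group Added to a Weak Urea

A few compounds are considered here, and "the series" means these few. Any claim that something is new, unique, unknown or untested is made for them only; others in the source may bear on it.

Compound 1 `O=C(Nc1ccc(CN2CCCCC2)cc1)Nc1ccc2ncnc(Nc3cccc(C(F)(F)F)c3)c2c1` and compound 2 `O=C(Nc1cccc(CN2CCCC2)c1)Nc1ccc2ncnc(Nc3cccc(C(F)(F)F)c3)c2c1` carry a cyclic amine, joined through a methylene, on the outer aromatic ring, while compound 3 `O=C(Nc1ccccc1)Nc1ccc2ncnc(Nc3cccc(C(F)(F)F)c3)c2c1` has a plain phenyl there. In a functional assay on A-431 cells (Homo sapiens) for antiproliferative activity, read by MTT assay, with a stated time of 72 h (a higher number here means a weaker inhibitor, a lower number a stronger inhibitor), compound 1 gives 1550 nM and compound 2 gives 1230 nM. Compound 3 reaches only > 10000 nM, which is a limit of the assay rather than a measured number (the limit of > 10000 nM in this assay, at which 1 of the 3 values shown sits). The two changes that lead to compound 3 both weakened inhibition: an at least 6.4-fold higher number from compound 1 to compound 3 (0.80 log units; beyond the scatter) and an at least 8.1-fold higher number from compound 2 to compound 3 (0.91 log units; beyond the scatter).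

Compound 4 `Cc1ccc(NC(=O)Nc2ccc3ncnc(Nc4cccc(C(F)(F)F)c4)c3c2)cc1` differs from compound 3 in one place: methyl in place of hydrogen on an aromatic carbon. The measured steps concern removing a ring-bearing group from this position, not adding a single carbon, so they bear on the change only loosely. Because compound 3 already stands at > 10000 nM, there is little room for the number to rise. The expected step of a number no higher from compound 3 to compound 4 (the limit leaves the size open) is therefore none beyond the scatter. Compound 4 is expected to give about 10000 nM, within a range from 3000 nM to 30000 nM, and may well return only a limit again.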

Compound 4, half-maximal inhibitory concentration: > 10000 nM
Compound 4 ended at the assay's limit; the forecaster's own chance of this, stated with the estimate: 60%; the middle value lies on the limit itself.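

Set against the ureas that carry a cyclic amine, a lone methyl on the outer ring leaves inhibition weak in this assay, with an at least 8.1-fold higher number from compound 2 to compound 4 (0.91 log units; beyond the scatter) and an at least 6.4-fold higher number from compound 1 to compound 4 (0.80 log units; beyond the scatter). A single added carbon, para to a large group, therefore does not do the work of a (pyrrolidin-1-yl)methyl or (piperidin-1-yl)methyl group in these compounds. The step from compound 3 to compound 4 cannot be read, because both values are limits of the assay and not numbers: the limit of > 10000 nM in this assay, at which 2 of the 4 values shown sit.

Whether methyl shifts activity at all, in either direction, stays hidden behind those limits. Also open, on these data alone, is whether a different group at this place, such as a carboxylic acid or an amine set directly on the ring, would give a measurable number.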